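The source may hold more compounds than are shown below. What is called first, only, known or untested is meant among the compounds shown, and "the series" means these compounds.

Measured compounds in an assay on cell membranes for binding affinity to 2-oxoglutarate receptor 1 (Rattus norvegicus), read by radioligand binding; a higher number here means a weaker inhibitor, a lower number a stronger inhibitor:
compound 1 `CCCCCCCNC(=O)[C@H]1OC(n2cnc3c(N)ncnc32)[C@H](O)[C@@H]1O`: 20 nM
compound 3 `Nc1ncnc2c1ncn2[C@@H]1O[C@H](C(=O)NC2CCCC2)[C@@H](O)[C@H]1O`: 49 nM
compound 2 `CCCCCCCCCCCCNC(=O)[C@H]1OC(n2cnc3c(N)ncnc32)[C@H](O)[C@@H]1O`: 163 nM

Compound 1 has the lowest number of the three in this assay. Compound 3, the nearest, shows a higher number, beyond the scatter; compound 2 stands furthest, the gap from compound 1 to compound 2 being an 8.2-fold higher number from compound 1 to compound 2 (0.91 log units; beyond the scatter), with pentyl in place of hydrogen on a saturated chain carbon, seven bonds along the chain from the amide-type nitrogen.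

The next compound, compound 4 `Nc1ncnc2c1ncn2C1O[C@H](C(=O)NC2CCCCCCC2)[C@@H](O)[C@H]1O`, differs from compound 1 by cyclooctyl in place of heptyl on an amide-type nitrogen. Going by the values given here, no measured pair changes heptyl for a ring of this size. Among the compounds with values here, the only step on record, from compound 1 to compound 2, adds to the chain and raises the number. The values of compound 1 and compound 3 show that a five-membered ring on the amide nitrogen gives a somewhat higher number than heptyl, still beyond the scatter. Cyclooctyl lies between those two cases by atom count, so a small loss or no change beyond the scatter is expected, giving an estimated step of a 1.6-fold higher number from compound 1 to compound 4 (0.20 log units; within the scatter). For compound 4 the expected value in this assay is 32 nM, with a range from 10 nM to 100 nM.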

Compound 4, inhibition constant: 23 nM
Compound 4: middle estimate off by 1.4-fold (0.14 log units), on the high side; low and high end bracket the measured number.
By their numbers in this assay, from the lowest: compounds 1 and 4 (each within the scatter of the next); then compound 3; then compound 2.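

In this assay, the step to the ring at the amide-type nitrogen is a 1.2-fold higher number from compound 1 to compound 4 (0.06 log units; within the scatter), so cyclooctyl and heptyl cannot be told apart at this position. Going by these compounds alone, until now the only step at this nitrogen was the lengthening of the chain, an 8.2-fold higher number from compound 1 to compound 2 (0.91 log units; beyond the scatter), which showed that the position can lose affinity; the new pair shows that an open chain is not required here, since one eight-membered non-aromatic ring of carbon only takes the place of heptyl with no change beyond the scatter. Nothing on hand explains why the two groups read alike at this position.

The compounds shown leave open whether a phenyl ring on the amide-type nitrogen would read like cyclooctyl, and whether an amine or a carboxylic acid at the far end of the heptyl chain would keep the value of compound 1 at 20 nM. They also leave open what a methyl group in place of the amide hydrogen would do, with heptyl or cyclooctyl kept on the same nitrogen.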